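The source may hold more compounds than are shown below. What is called first, only, known or untested is meant among the compounds shown, and "the series" means these compounds.

Working notes on the series.

Compound 2 `CN(C)CCn1cnnc1-c1cc(Oc2ccc(NC(=O)N/N=C/c3ccc(F)cc3)cc2F)ccn1` carries the shared core with 4-fluorophenyl on a carbon with a double bond to nitrogen. In a functional assay on NCI-H460 cells (Homo sapiens) for cytotoxicity, read by MTT assay, with a stated time of 72 h (a lower number here means a stronger inhibitor, a higher number a weaker inhibitor), compound 2 gives 1980 nM, which is the higher of the two numbers measured. Its nearest neighbour is compound 1 `CN(C)CCn1cnnc1-c1cc(Oc2ccc(NC(=O)N/N=C/c3ccccc3O[N+](=O)[O-])cc2F)ccn1`, which bears 2-(nitrooxy)phenyl at the same carbon; in this assay compound 1 gives 1270 nM. Among the measured compounds shown here, the one step measured between them is a 1.6-fold higher number from compound 1 to compound 2 (0.19 log units; within the scatter), so the two aryl groups seen so far cannot be told apart on these numbers.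

Compound 3 `CN(C)CCn1cnnc1-c1cc(Oc2ccc(NC(=O)N/N=C/c3cccc(Br)c3)cc2F)ccn1` has not yet been measured. It differs from compound 2 in one place: 3-bromophenyl in place of 4-fluorophenyl on a carbon with a double bond to nitrogen. For the measured compounds named here, no measured step covers a bromophenyl, and the only step that touches this position, a 1.6-fold higher number from compound 1 to compound 2 (0.19 log units; within the scatter), stayed within the scatter even though the aryl group changed more there than it does here. On that basis no step beyond the scatter is expected in this assay from the change to compound 3, in either direction; the expected step is a 1.1-fold lower number from compound 2 to compound 3 (0.04 log units; within the scatter). Compound 3 is therefore estimated at 1800 nM, with a range from 700 nM to 4500 nM.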

Compound 3, half-maximal inhibitory concentration: 520 nM
The estimate for compound 3 lay 3.5-fold (0.54 log units) above the measured number; measured number below the stated range.
By their numbers in this assay, from the lowest: compound 3; then compounds 1 and 2 (each within the scatter of the next).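

In this assay, among the compounds shown here, the aryl group on the carbon with a double bond to nitrogen now makes a measurable difference: the change to 3-bromophenyl gives two steps beyond the scatter, both modest in size (a 3.8-fold lower number from compound 2 to compound 3 (0.58 log units; beyond the scatter); a 2.4-fold lower number from compound 1 to compound 3 (0.39 log units; beyond the scatter)), whereas the one earlier step at this carbon stayed within the scatter. The position is therefore not indifferent to the aryl group, and among the three compounds shown, 3-bromophenyl is the only group that separates from the others. The larger step comes from a swap in which the computed counts of heavy atoms, hydrogen-bond donors and hydrogen-bond acceptors, and the net charge, are the same for the group leaving and the group entering, so those counts do not distinguish the two groups, and no supporting data bear on the origin of the shift.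

The change from 4-fluorophenyl to 3-bromophenyl alters both the halogen and its place on the ring, so the compounds shown cannot say which of the two goes with the lower number; 3-fluorophenyl and 4-bromophenyl would separate them. Also open, going by these compounds, is whether the trend extends to 3-chlorophenyl, or whether a phenyl carrying an amine or a carboxylic acid at this carbon would behave as 3-bromophenyl does.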